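Selenocyanate and diselenide aryl carbamates: cytotoxicity notes

The source may report more compounds than this note shows. Statements on the series, on what has been measured and on what is new or still open speak of the compounds shown alone.

Measured so far:
compound 1 `CCCOC(=O)Nc1ccc([Se]C#N)cc1` — 68800 nM
compound 2 `O=C(Nc1ccc([Se][Se]c2ccc(NC(=O)OCc3ccc([N+](=O)[O-])cc3)cc2)cc1)OCc1ccc([N+](=O)[O-])cc1` — 68100 nM
compound 3 `CCCCOC(=O)Nc1ccc([Se][Se]c2ccc(NC(=O)OCCCC)cc2)cc1` — 72300 nM

Going by the values given here, the three compounds so far have been tested in a functional assay on CCRF-CEM cells (Homo sapiens) for cytotoxicity, read by MTT assay, with a stated time of 72 h; a higher number here means that more compound is tolerated, a lower number that less compound is tolerated. Compound 1 gives 68800 nM in this assay, and compound 2 and compound 3, though built as diselenides rather than selenocyanates and carrying different carbamate esters, give numbers that sit close to it; the gap from compound 1 to compound 2 and the gap from compound 1 to compound 3 both lie within the usual scatter of the measurement. Nothing in these three numbers separates the compounds from one another.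

Compound 4 `CCOC(=O)Nc1ccc([Se]C#N)cc1` has not yet been measured in this assay. Relative to compound 1 the change is small: hydrogen in place of methyl on a saturated chain carbon, two bonds along the chain from an oxygen next to a carbonyl group. The carbamate is shortened by one chain carbon, with no change to the selenocyanate, the aromatic core or the carbamate itself.

Among the compounds with values here, no step between measured compounds is available to calibrate this kind of change. Given that compound 1 gives 68800 nM and that the two larger structural departures seen in compound 2 and compound 3 also leave the number essentially unchanged, no step beyond the scatter is expected for compound 4; the estimated step of a 1.0-fold higher number from compound 1 to compound 4 (0.01 log units; within the scatter) is expected to be effectively flat. Compound 4 is estimated at 70000 nM, with a likely range from 35000 nM to 140000 nM.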

Compound 4, concentration lethal to 50% of the cells: 68800 nM
Estimate against measurement, compound 4: 1.0-fold (0.01 log units) above, within the range that was stated.
By their numbers in this assay, from the lowest: compounds 2, 1, 4 and 3 (each within the scatter of the next).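

The change of hydrogen in place of methyl on a saturated chain carbon, two bonds along the chain from an oxygen next to a carbonyl group, gives in this assay no change at the digits printed from compound 1 to compound 4 (within the scatter) with the selenocyanate, the carbamate and the shared core left as they stand. The earlier compounds shown here offered no pair differing in one place, so no single change could be read on its own; this pair gives the first such reading, and it shows that going from propoxy to ethoxy at this position leaves the number flat in this cell assay. No measured evidence here bears on why the step is flat.

A single step of this size leaves open how far the chain can be altered at this position, for example with an octyl chain, a branched isopropyl group, or an amine or a carboxylic acid at the chain end. Also open, as far as these compounds go, is whether propoxy to ethoxy reads the same way on a diselenide, since the pair at hand covers only the selenocyanate.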